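Series notes: methylsulfonyl in place of methyl on compound 1

The source may hold more compounds than are shown below. What is called first, only, known or untested is meant among the compounds shown, and "the series" means these compounds.

Measured compounds:
compound 1 `Cc1cccc(C(=O)N2CCCC(C(=O)Nc3ccc(Cl)cc3)C2)c1`: 0%
compound 2 `O=C(Nc1cccc(Cc2ccccc2)c1)C1CCCN(C(=O)c2cccc(-c3ccco3)c2)C1`: 0%
compound 3 `O=C(Nc1ccc(Cl)nc1)C1CCCN(C(=O)c2cc(C(F)(F)F)cc(C(F)(F)F)c2)C1`: 25%

All three numbers come from an ADME assay on PC-3 cells (Homo sapiens) for cytotoxicity, read by WST assay, tested at 100 uM; on this read-out higher numbers stand for more inhibition at the one concentration tested (going by the name of the read-out) and lower numbers for less inhibition. Compound 1 and compound 2 stand level at the digits shown, together the lowest of the three, with the gap between them within the scatter. Compound 3 stands higher than both, by a gap beyond the scatter. Within the data shown here, no pair of the measured compounds differs in one place only, so no measured step is available to lean on.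

The unmeasured compound 4 `CS(=O)(=O)c1cccc(C(=O)N2CCCC(C(=O)Nc3ccc(Cl)cc3)C2)c1` differs from compound 1 in one place: methylsulfonyl in place of methyl on an aromatic carbon. The change sits on an aromatic carbon of a six-membered aromatic ring of carbon only, meta to a large group.

Among the measured compounds shown here, no measured step of this kind exists in the set. The step of a number 3 percentage points higher from compound 1 to compound 4 (within the scatter) is expected to be small, within the scatter, in no sure direction. Compound 4 is estimated at 3%, within the range -8% to 18%.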

Compound 4, a percentage reported as inhibition, at one concentration (the size of the read-out at that concentration, not a potency): 2%
Compound 4: middle estimate off by 1 percentage points, on the high side, within the range that was stated.
By their numbers in this assay, from the lowest: compounds 1, 2 and 4 (each within the scatter of the next); then compound 3.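

In this assay, among these compounds, the one-place change of methyl to methylsulfonyl gives the first readable step, a number 2 percentage points higher from compound 1 to compound 4 (within the scatter), and it lies within the scatter. Among the compounds shown here, this position on the aromatic carbon therefore takes the 4 heavy atoms and 2 hydrogen-bond acceptors of methylsulfonyl with no read-out shift beyond the scatter, something the earlier compounds, which differ in more than one place, could not show. No supporting measurement bears on this result.

On these data alone, whether an amine or a carboxylic acid on the same aromatic carbon would also leave the read-out level remains open. For the compounds shown here, also open is whether the methylsulfonyl change would stay this small on the other parts of compound 3, the one compound standing apart at 25% in this series.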